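Working notes: changing the sulfonyl substituent of compound 1

A few compounds are considered here, and "the series" means these few. Any claim that something is new, unique, unknown or untested is made for them only; others in the source may bear on it.

- Compound 1 `O=S(=O)(NCC1COC1)c1cccc(-c2ccc3nccc(-c4ccncc4)c3n2)c1` gives 20000 nM
- Compound 2 `c1cc(-c2ccnc3ccc(NC4CC4)nc23)ccn1` gives 90000 nM

Both values come from a physicochemical assay for solubility, read by HPLC, using the shake flask method, measured as kinetic solubility, with a stated time of 20 h, at pH 6.5, tested at 200 uM (on this read-out higher numbers stand for higher solubility and lower numbers for lower solubility), and differ beyond the usual scatter. Compound 1 holds the lower number, at 20000 nM against compound 2 at 90000 nM in this pair. Compound 3 `O=S(=O)(c1cccc(-c2ccc3nccc(-c4ccncc4)c3n2)c1)N1CCC(O)CC1` carries 4-hydroxypiperidin-1-yl in place of ((oxetan-3-yl)methyl)amino on a sulfonyl sulfur and keeps the core of compound 1. Within the data shown here, no measured pair shows this change, so no clear direction is expected in this assay and the estimated step of a 1.1-fold lower number from compound 1 to compound 3 (0.05 log units; within the scatter) stays within the scatter. Compound 3 is expected at 18000 nM within an estimated range of 5000 nM to 60000 nM for this measurement.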

Compound 3, solubility: 10000 nM
Compound 3: middle estimate off by 1.8-fold (0.26 log units), on the high side; low and high end bracket the measured number.
By their numbers in this assay, from the lowest: compounds 3 and 1 (each within the scatter of the next); then compound 2.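

Swapping ((oxetan-3-yl)methyl)amino for 4-hydroxypiperidin-1-yl on the sulfonyl sulfur gives the first step read at this position in this assay (a 2.0-fold lower number from compound 1 to compound 3 (0.30 log units; within the scatter)). A six-membered non-aromatic ring can therefore replace the four-membered one here without a change beyond the scatter, so this swap does not separate the two compounds. No further data bear on this step.

Open, going by these compounds, is whether a basic amine such as piperazin-1-yl or a carboxylic acid on the sulfonyl sulfur would move the number beyond the scatter.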